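Indole acrylic acids: ring-nitrogen substitution and cytotoxicity

The source may hold more compounds than are shown below. What is called first, only, known or untested is meant among the compounds shown, and "the series" means these compounds.

Measured compounds:
compound 1 `O=C(O)/C(=C/c1c[nH]c2ccc(OCc3ccccc3)cc12)c1ccccc1` — "not determined" (no result reported)
compound 2 `COc1ccc(/C(=C\c2cn(C(C)=O)c3ccc(OCc4ccccc4)cc23)C(=O)O)cc1OC` — 54800 nM
compound 3 `COc1ccc(/C(=C\c2c[nH]c3ccc(OCc4ccccc4)cc23)C(=O)O)cc1` — "not determined" (no result reported)

In a functional assay on A549 cells (Homo sapiens) for cytotoxicity, read by MTT assay, with a stated time of 72 h (on this read-out higher numbers stand for weaker inhibition and lower numbers for stronger inhibition), compound 1 is recorded as "not determined" (no result reported). In this assay compound 3 is likewise recorded as "not determined" (no result reported), so only compound 2 carries a value. In this assay compound 2 gives 54800 nM. Compound 4 `COc1ccc(Cn2cc(/C=C(/C(=O)O)c3ccccc3)c3cc(OCc4ccccc4)ccc32)cc1` is not yet measured. The change from compound 1 to compound 4 is 4-methoxybenzyl in place of hydrogen on an aromatic nitrogen. Among the compounds with values here, no step between measured compounds is available, so the size of this step cannot be anchored; a step no larger than the usual scatter is expected in this assay, with no firm direction. Within the data shown here, for compound 4 the estimate is 40000 nM, expected to lie between 8000 nM and 150000 nM, resting on the single value of compound 2 54800 nM as the only reference.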

Compound 4, half-maximal inhibitory concentration: 1000 nM
Beside the measured number, compound 4's estimate is 40-fold (1.60 log units) above it; the whole stated range lies above it.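

In this assay, within the data shown here, compound 1 stands as "not determined" (no result reported) and so no step from it to compound 4 can be read. The compounds shown leave open what the 4-methoxybenzyl group contributes to cytotoxicity. Nothing at hand bears on the cause of the result.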